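The source may hold more compounds than are shown below. What is called first, only, known or untested is meant among the compounds shown, and "the series" means these compounds.

Of the compounds shown here, three have so far been measured in a functional assay on FM3A cells (Mus musculus) for inhibition, read by cell counting, with a stated time of 2 days; a lower number here means a stronger inhibitor, a higher number a weaker inhibitor. Compound 1 `COc1cccc(-c2nn3cc(-c4cccc(N)c4)nc3s2)c1` gives 29000 nM, compound 2 `C=C(Br)C(=O)Nc1cccc(-c2cn3nc(-c4ccc(C)cc4)sc3n2)c1` gives 1200 nM, and compound 3 `C=C(Br)C(=O)Nc1cccc(-c2cn3c(-c4ccccc4)csc3n2)c1` gives 1300 nM. Compound 2 has the lowest number of the three; compound 3 lies within the scatter of it, while compound 1 lies far beyond it. Compound 4 `C=C(Br)C(=O)Nc1cccc(-c2cn3nc(-c4ccc(Cl)cc4)sc3n2)c1` has not yet been measured and differs from compound 2 in a single place: chloro in place of methyl on an aromatic carbon. Going by the values given here, nothing among the measured compounds shows how this swap moves the numbers. No step beyond the scatter is expected. Compound 4 is therefore estimated at 1200 nM, with a likely range from 500 nM to 3000 nM. This estimate means an expected step of no change at the digits printed from compound 2 to compound 4 (within the scatter).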

Compound 4, half-maximal inhibitory concentration: 2000 nM
Beside the measured number, compound 4's estimate is 1.7-fold (0.22 log units) below it; low and high end bracket the measured number.
By their numbers in this assay, from the lowest: compounds 2, 3 and 4 (each within the scatter of the next); then compound 1.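

In this assay, going by these compounds alone, going from 4-methylphenyl to 4-chlorophenyl gives a 1.7-fold higher number from compound 2 to compound 4 (0.22 log units; within the scatter), the first step that can be read at this place, para to a large group. At this place, then, chloro can stand in for methyl without a change that can be told from ordinary assay scatter. Nothing shown explains this result. As far as these compounds go, what remains open is how an amine, a carboxylic acid or a longer chain at this place would fare. From the compounds shown here alone, whether any group here can produce a step beyond the scatter also remains unknown.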